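Swapping the aryl on the ring nitrogen of compound 2

This account rests on a few compounds, and the source may have more. Where it says the series, first, only, none or still open, it means among the compounds named here.

Compound 2 `CC(=O)Nc1ccc(-c2nc3c(c(=O)n(C)c(=O)n3C)n2-c2cccc(F)c2)cc1`: 900 nM
Compound 1 `COC(=O)Nc1ccc(-c2nc3c(c(=O)n(C)c(=O)n3C)n2-c2ccc(OC)cc2)cc1`: 1700 nM

Of the compounds shown here, two sharing the same fused core have been measured in a functional assay on T47D cells (Homo sapiens) for antiproliferative activity, read by MTT assay, with a stated time of 48 h; on this read-out lower numbers stand for stronger inhibition and higher numbers for weaker inhibition. Compound 2 `CC(=O)Nc1ccc(-c2nc3c(c(=O)n(C)c(=O)n3C)n2-c2cccc(F)c2)cc1` gives 900 nM in this assay, and compound 1 `COC(=O)Nc1ccc(-c2nc3c(c(=O)n(C)c(=O)n3C)n2-c2ccc(OC)cc2)cc1` gives 1700 nM. The two numbers lie within the usual scatter of each other, so compound 2 cannot be set apart from compound 1 on these figures.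

Compound 3 `COc1ccc(-n2c(-c3ccc(NC(C)=O)cc3)nc3c2c(=O)n(C)c(=O)n3C)cc1` has not yet been measured. It differs from compound 2 by 4-methoxyphenyl in place of 3-fluorophenyl on an aromatic nitrogen. Among the compounds with values here, no pair of measured compounds shows this exact change on its own; the only comparison at hand is that compound 1, which carries the same 4-methoxyphenyl group, gives 1700 nM. On that basis the step is expected to be small, roughly a 1.6-fold higher number from compound 2 to compound 3 (0.19 log units; within the scatter), and not clearly beyond the scatter. Compound 3 is therefore estimated at 1400 nM, within a range from 500 nM to 4000 nM.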

Compound 3, half-maximal inhibitory concentration: 3700 nM
Estimate against measurement, compound 3: 2.6-fold (0.42 log units) below; the measured number falls inside the stated range.
By their numbers in this assay, from the lowest: compounds 2 and 1 (each within the scatter of the next); then compound 3.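

In this assay, within the data shown here, 4-methoxyphenyl in place of 3-fluorophenyl on the aromatic nitrogen gives a 4.1-fold higher number from compound 2 to compound 3 (0.61 log units; beyond the scatter), the first reading of this position with the rest of the molecule held fixed. Methyl in place of methoxy on a carbonyl carbon gives a 2.2-fold higher number from compound 1 to compound 3 (0.34 log units; beyond the scatter), so the numbers of compound 1 and compound 2, within the scatter of each other, conceal two separate steps of opposite direction along the path through compound 3. No measurement at hand accounts for either step.

From the compounds shown here alone, with only these two aryl groups at the nitrogen, it stays open whether the fluorine leaving, the methoxy entering or their ring positions set the step, which plain phenyl, 4-fluorophenyl or 3-methoxyphenyl could separate. Also open, going by these compounds, is whether the aryl swap gives a step of like size with methoxy rather than methyl on the carbonyl carbon.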